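A few compounds are considered here, and "the series" means these few. Any claim that something is new, unique, unknown or untested is made for them only; others in the source may bear on it.

Among the compounds with values here, compound 1 `COc1ccc(-c2c(S(=O)(=O)c3ccc(F)c(Cl)c3)cnc3cc(F)ccc23)cc1` is one of two compounds measured so far in an ADME assay on microsomes from liver (Homo sapiens) for metabolic stability, tested at 2.5 uM (a lower number here means slower removal, a higher number faster removal of the compound), and in that assay compound 1 gives 1.08 mL/min, the higher of the two numbers. Within the data shown here, its nearest neighbour is compound 2 `O=S(=O)(c1ccc(F)c(Cl)c1)c1cnc2cc(F)ccc2c1-c1ccc(Cl)cc1`, which in this assay gives 0.39 mL/min; the single change between them, chloro in place of methoxy on an aromatic carbon, brings a 2.8-fold lower number from compound 1 to compound 2 (0.44 log units; beyond the scatter).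

Compound 3 `COc1ccc(-c2c(S(=O)(=O)c3cccc(C#N)c3)cnc3cc(F)ccc23)cc1` has not been measured. Compared with compound 1 it differs as follows: 3-cyanophenyl in place of 3-chloro-4-fluorophenyl on a sulfonyl sulfur. Among the measured compounds shown here, this change sits on the sulfonyl sulfur, whereas the one measured step between compound 1 and compound 2 alters a different part of the molecule, so no measured step speaks directly to what a new group on the sulfonyl sulfur does in this assay. For the measured compounds named here, the only guidance is that the one recorded change of an aromatic substituent moved the number modestly, and a swap of similar size is therefore expected to stay close to compound 1, with no step clearly beyond the scatter in either direction. On that basis compound 3 is estimated at 1 mL/min, within a range of 0.5 mL/min to 2.2 mL/min, which would mean an expected step of a 1.1-fold lower number from compound 1 to compound 3 (0.03 log units; within the scatter).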

Compound 3, intrinsic clearance in a liver preparation (reported as CLH), per the amount of preparation that the assay uses: 0.92 mL/min
The estimate for compound 3 lay 1.1-fold (0.04 log units) above the measured number; low and high end bracket the measured number.
By their numbers in this assay, from the lowest: compound 2; then compounds 3 and 1 (each within the scatter of the next).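

In this assay, within the data shown here, the first look at the group on the sulfonyl sulfur gives a 1.2-fold lower number from compound 1 to compound 3 (0.07 log units; within the scatter), so 3-cyanophenyl and 3-chloro-4-fluorophenyl cannot be told apart here, even though the nitrile-bearing ring carries neither the chlorine nor the fluorine. Among these compounds, the one earlier step, at another place in the molecule, gave a 2.8-fold lower number from compound 1 to compound 2 (0.44 log units; beyond the scatter), which lies beyond the scatter, so the assay can register a single change, and this swap on the sulfonyl sulfur simply did not produce a readable one. Nothing measured here offers an explanation for how closely the two groups match.

Both groups shown on the sulfonyl sulfur are six-membered aromatic rings of carbon, so it remains open what a group of another kind, such as a simple alkyl chain or a ring holding an amine, would do at this position. From the compounds shown here alone, it also remains open whether 3-cyanophenyl would behave the same way alongside the chloro group of compound 2, since that pairing would show whether the two places act independently.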